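Shortening the Chain on the Ring Nitrogen

The source may report more compounds than this note shows. Statements on the series, on what has been measured and on what is new or still open speak of the compounds shown alone.

Among the compounds with values here, compound 2 `CCCCn1ncc(OCc2nnc(-c3ccccc3)o2)c(Cl)c1=O` and compound 1 `CC(C)(C)n1ncc(OCc2nnc(-c3ccc(Br)cc3)o2)c(Cl)c1=O` share a core but differ in two places at once, so no single step joins them and their values can only be set side by side. In a functional assay on the whole organism for inhibition, with Mythimna separata as the target, with a stated time of 5 days (on this read-out higher numbers stand for an effect only at larger amounts of compound and lower numbers for an effect already at smaller amounts), compound 1 gives 21.4 ug/mL. In this assay compound 2 gives > 300 ug/mL, which is a limit of the assay rather than a number. Of the two values shown, compound 2 is the one that sits at the limit of > 300 ug/mL in this assay, at which 1 of the 2 values shown sits.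

Compound 3 `CCn1ncc(OCc2nnc(-c3ccccc3)o2)c(Cl)c1=O` has not yet been measured. It differs from compound 2 by hydrogen in place of ethyl on a saturated chain carbon, two bonds along the chain from an aromatic nitrogen. Within the data shown here, no measured pair with a change of this kind is available, so the size and direction of the step cannot be read off from known numbers. The step of an at least 1.5-fold lower number from compound 2 to compound 3 (0.17 log units; that floor lies within the scatter) is expected to be small and uncertain, because compound 2 itself stands at > 300 ug/mL and gives no firm starting point. Compound 3 is estimated at around 200 ug/mL, within a range from 30 ug/mL to 600 ug/mL, with a real chance that this assay again reports only a limit.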

Compound 3, half-maximal effective concentration: > 300 ug/mL
Compound 3 was reported as a limit; the forecaster's own chance of this, stated with the estimate: 55%; at least 1.5-fold (0.17 log units) between middle value and limit.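

Compound 2 and compound 3 both stand at a limit of this assay rather than at a number, so no step can be read between them: the limit of > 300 ug/mL in this assay, at which 2 of the 3 values shown sit.

Still open, from the compounds shown here alone, is whether hydrogen in place of ethyl at this place on the chain changes the effect at all, in either direction.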